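The source may report more compounds than this note shows. Statements on the series, on what has been measured and on what is new or still open speak of the compounds shown alone.

compound 1 `CCSC[C@@](O)([C@@H](Nc1cccc2nc(C)ccc12)c1ccc(C)cc1)C(F)(F)F` gives 2.51 nM
compound 2 `CCSC[C@@](O)([C@@H](Nc1cccc2nc(C)ccc12)c1ccc(OC)cc1)C(F)(F)F` gives 6.31 nM
compound 3 `CCSC[C@@](O)([C@@H](Nc1cccc2nc(C)ccc12)c1ccc(Cl)c(F)c1OC)C(F)(F)F` gives 1.59 nM

All three values come from a functional assay on THP-1 cells (Homo sapiens) (on this read-out higher numbers stand for weaker inhibition and lower numbers for stronger inhibition), and compound 2 stands highest among them. The gaps around it both lie beyond the scatter: a 2.5-fold higher number from compound 1 to compound 2 (0.40 log units; beyond the scatter) and a 4.0-fold lower number from compound 2 to compound 3 (0.60 log units; beyond the scatter) are the measured steps.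

Compound 4 `CCSC[C@@](O)([C@@H](Nc1cccc2nc(C)ccc12)c1ccc(Cl)c(F)c1O)C(F)(F)F` is still unmeasured. It differs from compound 2 by 4-chloro-3-fluoro-2-hydroxyphenyl in place of 4-methoxyphenyl, and the count is 4-chloro-3-fluoro-2-hydroxyphenyl in place of 4-methoxyphenyl on a saturated chain carbon bound to a nitrogen on an aromatic ring and a saturated chain carbon at that saturated chain carbon.

The closest guide is a 4.0-fold lower number from compound 2 to compound 3 (0.60 log units; beyond the scatter) as a modest step, where the entering group carries methoxy in place of the hydroxy of compound 4. Within the data shown here, no measured compound carries that hydroxy, so this part of the change is untested. The step of a 2.5-fold higher number from compound 1 to compound 2 (0.40 log units; beyond the scatter) is also modest.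

A lower number of similar modest size is therefore expected in this assay with a wide range. The estimated step is a 3.2-fold lower number from compound 2 to compound 4 (0.50 log units; beyond the scatter) on this read-out. The estimate for compound 4 is 2 nM with an expected range from 0.6 nM to 6.5 nM on this read-out.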

Compound 4, half-maximal inhibitory concentration: 20 nM
The estimate for compound 4 lay 10-fold (1.00 log units) below the measured number, outside the stated range (above it).
By their numbers in this assay, from the lowest: compounds 3 and 1 (each within the scatter of the next); then compound 2; then compound 4.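

In this assay, hydrogen in place of methyl on the oxygen on the aromatic ring gives a 13-fold higher number from compound 3 to compound 4 (1.10 log units; beyond the scatter) and is the only large step among these compounds, so the group on that oxygen matters strongly here. The 4-chloro-3-fluoro-2-hydroxyphenyl group also stands behind both simpler rings, with a 3.2-fold higher number from compound 2 to compound 4 (0.50 log units; beyond the scatter) and an 8.0-fold higher number from compound 1 to compound 4 (0.90 log units; beyond the scatter), so chloro and fluoro on the ring do not secure a low number without the methyl on that oxygen. No measurement shown here explains the rise.

Still open, going by these compounds, is whether ethoxy or an amino group in place of the hydroxy of compound 4 would restore the number of compound 3. Also open, on these data alone, is whether removing methyl from the oxygen of compound 2 to give a 4-hydroxyphenyl group would raise the number as well.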